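A dimethoxyphenyl swap on compound 1

The compounds below may be only part of what the source reports. "The series", "measured", "known", "first", "only" and "open" are said of these compounds alone.

Compound 1 `COc1ccc(OC)c(C2=C(c3cc(OC)c(OC)c(OC)c3)C(=O)CC2O[SiH2]C(C)(C)C)c1`: 5 ug/mL
Compound 2 `COc1ccc(C2=C(c3cc(OC)c(OC)c(OC)c3)C(=O)C(O[SiH2]C(C)(C)C)C2)cc1`: 5 ug/mL

In an ADME assay on HT-29 cells (Homo sapiens) for cytotoxicity, read by MTT assay, with a stated time of 72 h (on this read-out lower numbers stand for stronger inhibition and higher numbers for weaker inhibition), compound 1 stands level with compound 2, within the usual scatter. Compound 3 `COc1ccc(C2=C(c3cc(OC)c(OC)c(OC)c3)C(=O)CC2O[SiH2]C(C)(C)C)cc1OC` has the same atoms as compound 1, joined differently, with 3,4-dimethoxyphenyl in place of 2,5-dimethoxyphenyl on a double-bonded ring carbon. For the measured compounds named here, no measured step isolates this change, so only a weak basis exists for a prediction, and no shift beyond the scatter is expected in this assay. The estimated step of no change at the digits printed from compound 1 to compound 3 (within the scatter) is therefore small. For compound 3 the expected value is 5 ug/mL, with an estimated range from 1.5 ug/mL to 15 ug/mL.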

Compound 3, half-maximal inhibitory concentration: > 100 ug/mL
Compound 3 ended at the assay's limit; the forecaster's own chance of this, stated with the estimate: 5%; middle value at least 20-fold (1.30 log units) from the limit.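

In this assay, the arrangement of the groups on the aryl ring at this double-bonded ring carbon proves decisive: 3,4-dimethoxyphenyl in place of 2,5-dimethoxyphenyl gives an at least 20-fold higher number from compound 1 to compound 3 (1.30 log units; beyond the scatter). For the compounds shown here, the value of compound 3 is a limit of the assay and not a number: the limit of > 100 ug/mL in this assay, at which 1 of the 3 values shown sits. The two groups have the same heavy atoms and hydrogen-bond acceptors, yet this position clearly tells them apart, which the earlier compounds did not show. Still open, on these data alone, is which of the two methoxy placements carries the step, and whether a single methoxy, an amine or a carboxylic acid on this aryl ring would keep the level of compound 1.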